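Fluoropyridinyl in Place of Fluorophenyl on the Chain

This account rests on a few compounds, and the source may have more. Where it says the series, first, only, none or still open, it means among the compounds named here.

Compound 2 `O=S(=O)(/C=C/c1ccccc1F)c1ncccc1C(F)(F)F` gives 124 nM in an assay on U2OS cells for activation of nuclear factor erythroid 2-related factor 2 (Homo sapiens), read by chemiluminescence, with a stated time of 6 h (on this read-out lower numbers stand for an effect already at smaller amounts and higher numbers for an effect only at larger amounts of compound), the lowest of the two numbers obtained so far. Its nearest neighbour, compound 1 `O=S(=O)(/C=C/c1ccccc1F)c1ccccn1`, gives 1010 nM in this assay. For the measured compounds named here, the single measured step, an 8.1-fold lower number from compound 1 to compound 2 (0.91 log units; beyond the scatter), rests on trifluoromethyl in place of hydrogen on an aromatic carbon, and that group is kept in what follows.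

Compound 3 `O=S(=O)(/C=C/c1ncccc1F)c1ncccc1C(F)(F)F` differs from compound 2 by 3-fluoropyridin-2-yl in place of 2-fluorophenyl on a double-bonded chain carbon bound to a double-bonded chain carbon. Going by the values given here, no measured step bears on this change: the only step recorded concerns a different part of the shared core, so it offers no guide to the size or direction of this exchange. Compound 3 is therefore expected to show no step beyond the scatter, a 1.3-fold higher number from compound 2 to compound 3 (0.11 log units; within the scatter). For compound 3 the estimate in this assay is 160 nM, with a range from 50 nM to 500 nM.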

Compound 3, half-maximal effective concentration: 202 nM
For compound 3 the middle estimate is 1.3-fold (0.10 log units) below the measured one; the range from low to high includes it.
By their numbers in this assay, from the lowest: compounds 2 and 3 (each within the scatter of the next); then compound 1.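

In this assay, for the compounds shown here, the exchange of 2-fluorophenyl for 3-fluoropyridin-2-yl on a double-bonded chain carbon bound to a double-bonded chain carbon gives a 1.6-fold higher number from compound 2 to compound 3 (0.21 log units; within the scatter) and thus provides the first reading at this place, where compound 1 and compound 2 both carry 2-fluorophenyl. Within the compounds shown, this place therefore takes a six-membered aromatic ring with 1 hetero atom and 1 hydrogen-bond acceptor with no step beyond the scatter, while trifluoromethyl stays in place elsewhere on the shared core. No measurement offered here accounts for this outcome.

From the compounds shown here alone, whether an amine, a carboxylic acid or a longer chain could stand in place of 3-fluoropyridin-2-yl remains open. Also open, going by these compounds, is whether the same exchange would give a comparable step with hydrogen in place of trifluoromethyl.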